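A Side-Chain Swap Near the Limit of the Assay

The source may report more compounds than this note shows. Statements on the series, on what has been measured and on what is new or still open speak of the compounds shown alone.

Going by the values given here, in a functional assay on K562 cells (Homo sapiens) for antiproliferative activity, read by MTT assay, with a stated time of 48 h (on this read-out higher numbers stand for weaker inhibition and lower numbers for stronger inhibition), compound 2 `Cn1cc(C2=C(c3nn(CCn4ccnc4)c4ncccc34)C(=O)N(c3ccccc3)C2=O)c2ccccc21` gives 26400 nM, the only true number among the measured compounds. Compound 1 `Cn1cc(C2=C(c3nn(CCCn4cncn4)c4ncccc34)C(=O)N(c3ccccc3)C2=O)c2ccccc21` reports only a limit, > 100000 nM. Compound 3 `Cn1cc(C2=C(c3nn(CCCN4CCCCC4)c4ncccc34)C(=O)N(c3ccccn3)C2=O)c2ccccc21` also reports only a limit, > 100000 nM. What surrounds compound 2 is therefore (the limit of > 100000 nM in this assay, at which 2 of the 3 values shown sit).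

Compound 4 `CN(C)CCCn1nc(C2=C(c3cn(C)c4ccccc34)C(=O)N(c3ccccc3)C2=O)c2cccnc21` keeps the core of compound 2 and alters the end of its side chain: (dimethylamino)methyl in place of 1H-imidazol-1-yl on a saturated chain carbon, two bonds along the chain from an aromatic nitrogen. In words, this places (dimethylamino)methyl in place of 1H-imidazol-1-yl on a saturated chain carbon, two bonds along the chain from an aromatic nitrogen.

Among the compounds with values here, only one measured step bears directly on this site: an at least 3.7-fold lower number from compound 1 to compound 2 (0.57 log units; beyond the scatter). That step shows that a change in this side chain can move the read-out, but it involves a different group and gives no size for the present swap. Compound 3, with > 100000 nM, differs from compound 4 in more than one place, so it offers only a weak hint towards weaker inhibition.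

The expected change is small and within the scatter, with a slight lean towards a higher number: a 1.5-fold higher number from compound 2 to compound 4 (0.18 log units; within the scatter). For compound 4 the estimated value in this assay is 40000 nM, with an expected range of 10000 nM to 100000 nM.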

Compound 4, half-maximal inhibitory concentration: 1700 nM
Compound 4: middle estimate off by 24-fold (1.37 log units), on the high side; measured number below the stated range.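

In this assay this side chain proves able to carry a large change rather than only the modest one seen before: 3-(dimethylamino)propyl in place of 2-(1H-imidazol-1-yl)ethyl gives a 16-fold lower number from compound 2 to compound 4 (1.19 log units; beyond the scatter). Compound 1 stands at a limit of the assay, > 100000 nM, and not at a true number. Dimethylamino in place of 1H-1,2,4-triazol-1-yl, on a saturated chain carbon three bonds along the chain from an aromatic nitrogen, gives an at least 58-fold lower number from compound 1 to compound 4 (1.76 log units; beyond the scatter), so among these three compounds the side chain whose end has no ring gives the lowest number.

Compound 3 also reports only a limit, > 100000 nM, and it differs from compound 4 in more than one place, so it cannot show whether an amine at the chain end is enough on its own. Whether the gain belongs to the end group or to the longer chain remains open, as does whether a 2-(dimethylamino)ethyl chain or a morpholine end would keep it, and the values shown give little to go on: the limit of > 100000 nM in this assay, at which 2 of the 4 values shown sit.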